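Varying the benzylic aryl group of a cyano-pyridine lactone series

The compounds below may be only part of what the source reports. "The series", "measured", "known", "first", "only" and "open" are said of these compounds alone.

Measured compounds:
Compound 1, `N#Cc1cc2c(nc1N1CCC(C(=O)NS(=O)(=O)Cc3ccccc3F)CC1)COC2=O`: 23700 nM
Compound 2, `N#Cc1ccc(CS(=O)(=O)NC(=O)C2CCN(c3nc4c(cc3C#N)C(=O)OC4)CC2)cc1`: 8900 nM
Compound 3, `N#Cc1cc2c(nc1N1CCC(C(=O)NS(=O)(=O)Cc3cccc(F)c3)CC1)COC2=O`: 70500 nM

Three compounds sharing one core were measured in a functional assay (Platelet, plasma) for inhibition, with Homo sapiens as the target (a lower number here means a stronger inhibitor, a higher number a weaker inhibitor), differing only in the aryl group on a saturated chain carbon bound to a sulfonyl sulfur. Compound 3 stands highest of the three: compound 1 lies nearest, as a 3.0-fold higher number from compound 1 to compound 3 (0.47 log units; beyond the scatter) shows, and compound 2 lies furthest, as a 7.9-fold higher number from compound 2 to compound 3 (0.90 log units; beyond the scatter) shows. Compound 2, with 4-cyanophenyl, gives the lowest number, and a 2.7-fold lower number from compound 1 to compound 2 (0.43 log units; beyond the scatter) separates it from compound 1.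

Compound 4, `N#Cc1cc2c(nc1N1CCC(C(=O)NS(=O)(=O)Cc3ccc(Cl)cc3)CC1)COC2=O`, has not yet been measured in this assay. It differs from compound 3 as follows: 4-chlorophenyl in place of 3-fluorophenyl on a saturated chain carbon bound to a sulfonyl sulfur. Among the compounds with values here, two measured steps bear on this change, both ending at compound 3 and both pointing the same way: each move away from 3-fluorophenyl to another aryl group gave a lower number, modestly with 2-fluorophenyl and more strongly with 4-cyanophenyl. Within the data shown here, a 4-chlorophenyl group has no direct precedent here, so the size of its effect remains uncertain, but a lower number beyond the scatter is expected. The estimated step is a 3.9-fold lower number from compound 3 to compound 4 (0.59 log units; beyond the scatter), and compound 4 is expected to give 18000 nM, within a range from 6000 nM to 50000 nM.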

Compound 4, half-maximal inhibitory concentration: 4420 nM
For compound 4 the middle estimate is 4.1-fold (0.61 log units) above the measured one; measured number outside the range, below it.
By their numbers in this assay, from the lowest: compounds 4 and 2 (each within the scatter of the next); then compound 1; then compound 3.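

In this assay, within the data shown here, the aryl group on a saturated chain carbon bound to a sulfonyl sulfur proves able to move the number much further than the earlier compounds showed: 4-chlorophenyl in place of 3-fluorophenyl gives the only large step in the set (a 16-fold lower number from compound 3 to compound 4 (1.20 log units; beyond the scatter)), and in place of 2-fluorophenyl it gives a modest one (a 5.4-fold lower number from compound 1 to compound 4 (0.73 log units; beyond the scatter)). Chloro in place of cyano on an aromatic carbon stays within the scatter (a 2.0-fold lower number from compound 2 to compound 4 (0.30 log units; within the scatter)), so compounds 2 and 4, with the 4-cyanophenyl and 4-chlorophenyl groups, stand together below compounds 1 and 3, with their fluorophenyl groups, and none of the four goes against this split. Nothing given here speaks to the reason for a step of this size.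

Because the 4-chlorophenyl group differs from 3-fluorophenyl in both its halogen and its place on the ring, these compounds cannot separate the two, and 4-fluorophenyl and 3-chlorophenyl groups would be needed to do so. As far as these compounds go, how an unsubstituted phenyl or a 4-methoxyphenyl group would compare also remains open.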